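Sulfonyl aryl variation: toward 3-chloro-4-methylphenyl

This account rests on a few compounds, and the source may have more. Where it says the series, first, only, none or still open, it means among the compounds named here.

Compound 1 `CC(C)(C)NCc1ccc2c(c1)CCC[C@H]2NC(=O)C[C@@H]1CCCCN1S(=O)(=O)c1ccccc1` carries an unsubstituted phenyl on the sulfonyl sulfur; in an assay on isolated protein for inhibition of B1 bradykinin receptor (Homo sapiens) (on this read-out lower numbers stand for stronger inhibition and higher numbers for weaker inhibition), compound 1 gives 1700 nM. Compound 2 `CC(C)(C)NCc1ccc2c(c1)CCC[C@H]2NC(=O)C[C@@H]1CCCCN1S(=O)(=O)c1ccc(Cl)cc1` gives 560 nM, and compound 3 `CC(C)(C)NCc1ccc2c(c1)CCC[C@H]2NC(=O)C[C@@H]1CCCCN1S(=O)(=O)c1cccc(Cl)c1` gives 120 nM. Compound 2 thus stands second highest of the three numbers: a 3.0-fold lower number from compound 1 to compound 2 (0.48 log units; beyond the scatter) separates it from compound 1, a 4.7-fold lower number from compound 2 to compound 3 (0.67 log units; beyond the scatter) separates it from compound 3, and a 14-fold lower number from compound 1 to compound 3 (1.15 log units; beyond the scatter) spans the whole set.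

Compound 4 `Cc1ccc(S(=O)(=O)N2CCCC[C@H]2CC(=O)N[C@@H]2CCCc3cc(CNC(C)(C)C)ccc32)cc1Cl` is not yet measured. (3-chloro-4-methylphenyl in place of 4-chlorophenyl on a sulfonyl sulfur). Within the data shown here, the step that bears most directly is a 4.7-fold lower number from compound 2 to compound 3 (0.67 log units; beyond the scatter), since the 3-chloro-4-methylphenyl of compound 4, like the 3-chlorophenyl of compound 3, replaces 4-chlorophenyl; the added methyl has no counterpart among the measured compounds. Compound 3 at 120 nM is therefore the nearest anchor, with no guidance on the methyl. A lowering beyond the scatter is expected, roughly following the path to compound 3, with a widened range. Compound 4 is expected at 150 nM (range 50 nM to 500 nM). This amounts to an expected step of a 3.7-fold lower number from compound 2 to compound 4 (0.57 log units; beyond the scatter).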

Compound 4, half-maximal inhibitory concentration: 15 nM
Beside the measured number, compound 4's estimate is 10-fold (1.00 log units) above it, outside the stated range (below it).
By their numbers in this assay, from the lowest: compound 4; then compound 3; then compound 2; then compound 1.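

In this assay the sulfonyl aryl group responds to more than a single chloro: going from the 3-chlorophenyl to the 3-chloro-4-methylphenyl gives an 8.0-fold lower number from compound 3 to compound 4 (0.90 log units; beyond the scatter), a step the chloro compounds alone could not show. Among these compounds, measured against the 4-chlorophenyl, the same aryl group gives a 37-fold lower number from compound 2 to compound 4 (1.57 log units; beyond the scatter), and against the unsubstituted phenyl it gives a 110-fold lower number from compound 1 to compound 4 (2.05 log units; beyond the scatter), so this sulfonyl position spans a much wider range than the earlier compounds indicated. Nothing at hand accounts for these steps.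

As far as these compounds go, it remains open whether 4-methylphenyl, carrying no chloro, would give a similar number or whether the methyl step depends on the chloro. Also open, from the compounds shown here alone, is how ethyl or methoxy in place of the methyl, or fluoro in place of the chloro, would read.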